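This account rests on a few compounds, and the source may have more. Where it says the series, first, only, none or still open, it means among the compounds named here.

Working notes on the shared core of compound 2 `O=S(=O)(NCCCNCc1ccccc1)c1cc(C(F)(F)F)cc(C(F)(F)F)c1`. In a functional assay on Capan-2 cells (Homo sapiens) for inhibition, read by MTT assay, with a stated time of 72 h (on this read-out lower numbers stand for stronger inhibition of growth and higher numbers for weaker inhibition of growth), compound 2 gives 14000 nM, the highest number of the three measured; compound 1 `CC(C)(C)c1ccc(CNCCCNS(=O)(=O)c2cc(C(F)(F)F)cc(C(F)(F)F)c2)cc1` gives 2100 nM and compound 3 `O=S(=O)(NCCCNCc1cccc2ccccc12)c1cc(C(F)(F)F)cc(C(F)(F)F)c1` gives 2700 nM. Compound 4 `O=S(=O)(NCCCNCc1ccc(-c2ccccc2)cc1)c1cc(C(F)(F)F)cc(C(F)(F)F)c1` differs from compound 2 by phenyl in place of hydrogen on an aromatic carbon. Going by the values given here, two measured steps bear on this change: a 6.7-fold higher number from compound 1 to compound 2 (0.82 log units; beyond the scatter) and a 5.2-fold lower number from compound 2 to compound 3 (0.71 log units; beyond the scatter). Among the compounds with values here, both show that a larger group on the saturated chain carbon bound to the amine nitrogen goes with a lower number, and no measured compound runs against that. A drop of similar size is therefore expected in this assay, a 4.7-fold lower number from compound 2 to compound 4 (0.67 log units; beyond the scatter). Compound 4 is estimated at 3000 nM, with a range of 1200 nM to 8000 nM.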

Compound 4, concentration for 50% growth inhibition: 2200 nM
Beside the measured number, compound 4's estimate is 1.4-fold (0.13 log units) above it, and the stated range covers the measured number.
By their numbers in this assay, from the lowest: compounds 1, 4 and 3 (each within the scatter of the next); then compound 2.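

In this assay, the step on this aromatic carbon, para to a large group, is a 6.4-fold lower number from compound 2 to compound 4 (0.80 log units; beyond the scatter), so a carbon-only aromatic ring there goes with a lower number, as tert-butyl does. Phenyl and tert-butyl at this place cannot be told apart, with a 1.0-fold higher number from compound 1 to compound 4 (0.02 log units; within the scatter). No measurement at hand accounts for either step. Going by these compounds, whether a group with heteroatoms on this carbon, such as an amine or a carboxylic acid, would also go with a lower number stays open. On these data alone, the effect of a longer chain in the core stays open as well.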